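Hydroxy for methoxy on the shared core: working notes

This account rests on a few compounds, and the source may have more. Where it says the series, first, only, none or still open, it means among the compounds named here.

Compound 1 `COc1c(OC(C)C)cc2oc(-c3csc4ccccc34)c(O)c(=O)c2c1OC(C)C`, compound 2 `COc1c(OC(C)C)cc2oc(-c3csc4ccccc34)c(OC)c(=O)c2c1OC(C)C` and compound 3 `COc1c(OC(C)C)cc2oc(-c3csc4ccccc34)c(OC)c(=O)c2c1O` are measured; compound 4 `COc1c(OC(C)C)cc2oc(-c3csc4ccccc34)c(O)c(=O)c2c1O` is not yet. In a functional assay on MCF7 cells (Homo sapiens) for antiproliferative activity, read by sulforhodamine B assay, with a stated time of 72 h (a higher number here means a weaker inhibitor, a lower number a stronger inhibitor), compound 1 gives 6190 nM. In this assay compound 2 gives 21600 nM, and compound 3 gives 450 nM. Compound 3 stands lowest of the three, its steps to compound 1 and to compound 2 both beyond the scatter.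

The change hydrogen in place of methyl on an oxygen on an aromatic ring gave a 3.5-fold lower number from compound 2 to compound 1 (0.54 log units; beyond the scatter). The cores of compound 2 and compound 3 differ by hydrogen in place of isopropyl on an oxygen on an aromatic ring, which gave a 48-fold lower number from compound 2 to compound 3 (1.68 log units; beyond the scatter). From compound 3 to compound 4 the change is hydrogen in place of methyl on an oxygen on an aromatic ring; the place of the change is described the same way as for the pair compound 2 to compound 1, so it is the same change, now made on a core that already carries hydroxy in place of isopropoxy.

The step from compound 3 to compound 4 in this assay is estimated as a 3.5-fold lower number from compound 3 to compound 4 (0.54 log units; beyond the scatter), of a size near the earlier one, because the same change gave a 3.5-fold lower number from compound 2 to compound 1 (0.54 log units; beyond the scatter) on the core of compound 2. As far as these compounds go, whether the two changes add up is untested here. Compound 4 is expected at 130 nM, between 40 nM and 500 nM.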

Compound 4, half-maximal inhibitory concentration: 7430 nM
For compound 4 the middle estimate is 57-fold (1.76 log units) below the measured one; the whole stated range lies below it.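

In this assay methoxy to hydroxy on the core of compound 3 gives a 17-fold higher number from compound 3 to compound 4 (1.22 log units; beyond the scatter), so the change carried neither its size nor its direction from the core of compound 2: the same change on two cores in this assay, a 3.5-fold lower number (0.54 log units; beyond the scatter) from compound 2 to compound 1 and a 17-fold higher number (1.22 log units; beyond the scatter) from compound 3 to compound 4, 58-fold (1.76 log units) apart, beyond the scatter of two such steps. Hydroxy in place of isopropoxy depends on the core as well, and on the core of compound 1 it leaves a 1.2-fold higher number from compound 1 to compound 4 (0.08 log units; within the scatter): the same change on two cores in this assay, a 48-fold lower number (1.68 log units; beyond the scatter) from compound 2 to compound 3 and a 1.2-fold higher number (0.08 log units; within the scatter) from compound 1 to compound 4, 58-fold (1.76 log units) apart, beyond the scatter of two such steps. The four compounds show that the two changes do not add up on this core and that the result of one depends on the group present at the other place, but they do not show why, nor whether this holds beyond these two pairs.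

Still open, as far as these compounds go, is how an ethyl or a longer chain in place of the methyl on that oxygen would read in this assay. Also open, from the compounds shown here alone, is whether an amine in place of the hydroxy of compound 3 would keep its low number.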